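Exchanging Dimethylamino for Phenyl: Expected Cytotoxicity Outcome

The compounds below may be only part of what the source reports. "The series", "measured", "known", "first", "only" and "open" are said of these compounds alone.

Compound 1, `CC(C)N(Cc1cccc(OCCCCCC(=O)O)c1)C(=O)c1ccc(-c2cccc(N(C)C)c2)cc1`, gives > 26000 nM in an ADME assay on HepG2 cells (Homo sapiens) for cytotoxicity, read by CellTiter-Glo and resazurin assay, with a stated time of 72 h; on this read-out higher numbers stand for an effect only at larger amounts of compound and lower numbers for an effect already at smaller amounts; this is a limit of the assay, not a measured number.
Compound 2, `CC(C)N(Cc1cccc(OCCCCCC(=O)O)c1)C(=O)c1ccc(-c2ccc(Cl)c(Cl)c2)cc1`, gives > 26000 nM in this assay; again this is only a limit.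
Compound 3, `CCOC(=O)CCCCCOc1cccc(CN(C(=O)c2ccc(-c3cccc(N(C)C)c3)cc2)C(C)C)c1`, gives > 26000 nM in this assay; this too is a limit.

Compound 3 therefore stands at the same limit as the other two measured compounds; none of the three shows an effect within the tested amounts, so there is no number to rank it by. The two measured steps are both unreadable for the same reason: the step that the two limits leave unreadable from compound 1 to compound 2 and the step that the two limits leave unreadable from compound 1 to compound 3 each run between two limits, and the limit of > 26000 nM in this assay, at which 3 of the 3 values shown sit, holds for every value shown.

Compound 4, `CCOC(=O)CCCCCOc1cccc(CN(C(=O)c2ccc(-c3cccc(-c4ccccc4)c3)cc2)C(C)C)c1`, differs from compound 3 in one place: phenyl in place of dimethylamino on an aromatic carbon. For the measured compounds named here, neither measured step says anything about a change of this kind, since both are hidden by the limit, and no value so far reaches a measurable effect. Going by the values given here, the only guide is that every compound in this set sits at the limit.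

From compound 3 to compound 4 the step is expected to be a step that the limit leaves unreadable from compound 3 to compound 4, that is, nothing readable. For compound 4 the estimate is 40000 nM, with a likely range of 15000 nM to 120000 nM, and most probably the assay will again report only a limit.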

Compound 4, half-maximal effective concentration: > 26000 nM
Compound 4 ended at the assay's limit; the forecaster's own chance of this, stated with the estimate: 80%; the middle value lies beyond the limit too.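

No step can be read from compound 3 to compound 4, since both values are only limits of the assay: the limit of > 26000 nM in this assay, at which 4 of the 4 values shown sit.

The compounds shown leave open at what amount any of them would show an effect in this assay, and so whether exchanging dimethylamino for phenyl changes that amount at all.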